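From tert-butyl to (1-methylcyclopropyl)methyl

This account rests on a few compounds, and the source may have more. Where it says the series, first, only, none or still open, it means among the compounds named here.

In a functional assay on a cell-free system (plasma, Homo sapiens), with a stated time of 3 min (a higher number here means a weaker inhibitor, a lower number a stronger inhibitor), compound 1 (`O=C(NCc1cc(Cl)ccc1-n1cnnn1)[C@@H]1[C@@H]2C[C@@H]2CN1C(=O)[C@H](O)Cc1ccccn1`) gives 1700 nM and compound 2 (`CC(C)(C)[C@@H](O)C(=O)N1C[C@H]2C[C@H]2[C@H]1C(=O)NCc1cc(Cl)ccc1-n1cnnn1`) gives 1200 nM with the two inside the scatter of each other. Compound 3 (`CC1(C[C@@H](O)C(=O)N2C[C@H]3C[C@H]3[C@H]2C(=O)NCc2cc(Cl)ccc2-n2cnnn2)CC1`) carries (1-methylcyclopropyl)methyl in place of tert-butyl on a saturated chain carbon bound to a carbonyl carbon and an oxygen on a saturated carbon. Among the measured compounds shown here, the one measured step at this place (a 1.4-fold lower number from compound 1 to compound 2 (0.15 log units; within the scatter)) brought in tert-butyl for (pyridin-2-yl)methyl and stayed within the scatter. For compound 3 a similarly small change with no clear direction is expected (a 1.2-fold lower number from compound 2 to compound 3 (0.08 log units; within the scatter)). In this assay compound 3 is estimated at 1000 nM within a range of 350 nM to 3000 nM as the expected span.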

Compound 3, half-maximal inhibitory concentration: 500 nM
Estimate against measurement, compound 3: 2.0-fold (0.30 log units) above, and the stated range covers the measured number.
By their numbers in this assay, from the lowest: compound 3; then compounds 2 and 1 (each within the scatter of the next).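

In this assay the step of a 2.4-fold lower number from compound 2 to compound 3 (0.38 log units; beyond the scatter) lies beyond the scatter, unlike the earlier step at this position, so exchanging tert-butyl for (1-methylcyclopropyl)methyl does move the number here, if only modestly. The step of a 3.4-fold lower number from compound 1 to compound 3 (0.53 log units; beyond the scatter) is also modest and beyond the scatter, with 1-methylcyclopropyl in place of pyridin-2-yl. No measurement shown explains this difference. The compounds shown leave open how an amine, a carboxylic acid or a longer chain at this place would compare. They also leave open whether the three-membered ring itself matters, since a plain chain of the same five carbons is not among them.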